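The source may hold more compounds than are shown below. What is called first, only, known or untested is meant among the compounds shown, and "the series" means these compounds.

Among the measured compounds shown here, compound 3 `C=CCCCCCCCC#CC#CCO` gives 3.9 ug/mL in a functional assay on A549 cells (Homo sapiens) for cytotoxicity (a higher number here means that more compound is needed for the effect, a lower number that less compound is needed), the lowest of the three numbers so far; compound 2 `C=CCCCCCCCC#CC#CC(O)CC(C)=O` gives 4.91 ug/mL and the two stand together, since a 1.3-fold lower number from compound 2 to compound 3 (0.10 log units; within the scatter) lies within the scatter, while compound 1 `C=CCCCCCC#CC#CCO` at 13.8 ug/mL sits apart: a 3.5-fold lower number from compound 1 to compound 3 (0.55 log units; beyond the scatter).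

Compound 4 `CCCCCCCC#CC#CCO` is compound 3 with hydrogen in place of vinyl on a saturated chain carbon, seven bonds along the chain from a triple-bonded carbon. For the measured compounds named here, only the step from compound 1 to compound 3 bears on this, and it runs the other way: lengthening the chain at that end gave a 3.5-fold lower number from compound 1 to compound 3 (0.55 log units; beyond the scatter). Shortening it is therefore expected to raise the number in this assay by a modest step, roughly a 2.1-fold higher number from compound 3 to compound 4 (0.31 log units; beyond the scatter), though a result within the scatter cannot be ruled out. Compound 4 is estimated at 8 ug/mL, range 3.5 ug/mL to 18 ug/mL.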

Compound 4, concentration for half-maximal effect: 5.48 ug/mL
For compound 4 the middle estimate is 1.5-fold (0.16 log units) above the measured one; the measured number falls inside the stated range.
By their numbers in this assay, from the lowest: compounds 3, 2 and 4 (each within the scatter of the next); then compound 1.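

Hydrogen in place of vinyl, on a saturated chain carbon seven bonds along the chain from a triple-bonded carbon, gives a 1.4-fold higher number from compound 3 to compound 4 (0.15 log units; within the scatter) in this assay, so at this position the vinyl group can go without a change beyond the scatter. Ethyl in place of vinyl, on a saturated chain carbon five bonds along the chain from a triple-bonded carbon, gives a 2.5-fold lower number from compound 1 to compound 4 (0.40 log units; beyond the scatter) and so, at that position, the change goes beyond the scatter. No measurement given here explains this difference between the two positions. Still open, going by these compounds, is how a longer saturated chain, or an amine or carboxylic acid in place of vinyl, would read in this assay.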